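The source may report more compounds than this note shows. Statements on the series, on what has been measured and on what is new or still open speak of the compounds shown alone.

Measured so far:
compound 1, `CN1CCN(c2nc(Cl)nc3c2ncn3Cc2ccc(C(=O)Nc3ccccc3N)cc2)CC1`: 1600 nM
compound 2, `CCC(C)n1cnc2c(NCc3ccc(C(=O)Nc4ccccc4N)cc3)nc(Cl)nc21`: 2880 nM

In a functional assay on A-375 cells (Homo sapiens) for antiproliferative activity, read by CCK-8 assay, with a stated time of 72 h (on this read-out higher numbers stand for weaker inhibition and lower numbers for stronger inhibition), compound 1 gives 1600 nM. Compound 2 gives 2880 nM, and the two numbers lie within the usual scatter of each other, so nothing separates them.

Compound 3, `CC1CCN(c2nc(Cl)nc3c2ncn3Cc2ccc(C(=O)Nc3ccccc3N)cc2)CC1`, has not been measured. It differs from compound 1 in one place: 4-methylpiperidin-1-yl in place of 4-methylpiperazin-1-yl on an aromatic carbon. Going by the values given here, no pair of measured compounds shows what such a change does here, so the step is expected to stay within the scatter, with no clear direction. Compound 3 is estimated at 2000 nM, in a range from 700 nM to 6000 nM, which means an expected step of a 1.3-fold higher number from compound 1 to compound 3 (0.10 log units; within the scatter).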

Compound 3, half-maximal inhibitory concentration: 4240 nM
Compound 3: middle estimate off by 2.1-fold (0.33 log units), on the low side; low and high end bracket the measured number.
By their numbers in this assay, from the lowest: compounds 1, 2 and 3 (each within the scatter of the next, the first and the last beyond it).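

In this assay, putting 4-methylpiperidin-1-yl in place of 4-methylpiperazin-1-yl on this aromatic carbon gives a 2.7-fold higher number from compound 1 to compound 3 (0.42 log units; beyond the scatter). This shows that the number at this position responds to a single ring atom, since the two groups are the same size and differ only in one ring nitrogen becoming carbon. No measurement here accounts for the difference.

As far as these compounds go, it remains open how other groups on this carbon would compare, such as morpholin-4-yl, piperazin-1-yl without the methyl, or an open-chain dimethylamino group.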